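A few compounds are considered here, and "the series" means these few. Any claim that something is new, unique, unknown or untested is made for them only; others in the source may bear on it.

Working notes on the series.

For the measured compounds named here, compound 1 `CCOC(=O)N1CCN(C(=S)Nc2ccnc3cc(Cl)ccc23)CC1` is the only member with a plain number in a functional assay on HeLa cells (Homo sapiens) for cytotoxicity, read by MTT assay, with a stated time of 7 h; a higher number here means a weaker inhibitor, a lower number a stronger inhibitor: compound 1 gives 40100 nM. Compound 2 `CCN1CCN(C(=S)Nc2ccnc3cc(Cl)ccc23)CC1` reaches only the limit of this assay, and compound 2 gives > 50000 nM, a limit rather than a number. Compound 3 `S=C(Nc1ccnc2cc(Cl)ccc12)N1CCNCC1` has no result in this assay, recorded as "not determined" (no result reported), so compound 3 cannot be placed on the numbers; what is known of the shared core comes from compound 1 and compound 2, both of which sit at weak inhibition, one of them at the limit of > 50000 nM in this assay, at which 1 of the 3 values shown sits.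

Compound 4 `S=C(Nc1ccnc2cc(Cl)ccc12)N1CCN(c2ccccc2)CC1` carries phenyl in place of hydrogen on an amine nitrogen in a ring. Going by the values given here, no measured step touches this change directly. Among the compounds with values here, the one measured step, an at least 1.2-fold higher number from compound 1 to compound 2 (0.09 log units; that floor lies within the scatter), concerns a different exchange on the same ring nitrogen and lies within the scatter, so it gives no direction for a change of that kind; it only shows that substitution at this position has not moved potency beyond the weak range of compound 1 and compound 2.

For compound 4 in this assay, a value in the same weak range is expected, estimated at 40000 nM, with a range from 12000 nM to 150000 nM, and a real chance that only a limit is reported.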

Compound 4, half-maximal inhibitory concentration: 43600 nM
Estimate against measurement, compound 4: 1.1-fold (0.04 log units) below; the measured number falls inside the stated range.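

Phenyl on this ring nitrogen puts an aromatic ring at the position, and in this assay the exchange for ethoxycarbonyl gives a 1.1-fold higher number from compound 1 to compound 4 (0.04 log units; within the scatter) and so separates the two groups by nothing that can be read. Compound 2 gives > 50000 nM as a limit and not a number, so the other step, an at least 1.1-fold lower number from compound 2 to compound 4 (0.05 log units; that floor lies within the scatter), fixes only a floor and sets no order between ethyl and phenyl. Compound 4 thus extends what compound 1 and compound 2 showed: with an aromatic ring here as well as the two open-chain groups, no exchange shown at this position moves the number beyond the scatter, and a plain number now stands in the weak range beside that of compound 1.

Going by these compounds, compound 3 has no result, so the effect of any of these groups against hydrogen on this nitrogen remains unknown. Also open, on these data alone, is whether a group of another kind in this place, such as a carboxylic acid, a primary amine at the end of a longer chain, or a phenyl carrying a methoxy group, would take the number out of the weak range.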